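Cytotoxicity notes on a side-chain series

The compounds below may be only part of what the source reports. "The series", "measured", "known", "first", "only" and "open" are said of these compounds alone.

Measured so far:
Compound 1 `CNc1nc(N)nc2ccccc12`: in an ADME assay on HEK293 cells (Homo sapiens) for cytotoxicity, with a stated time of 6 h (on this read-out higher numbers stand for lower toxicity in this test and lower numbers for higher toxicity in this test), compound 1 gives > 25000 nM, which is a limit of the assay.
Compound 2 `CCNc1nc(N)nc2ccccc12`: in this assay compound 2 gives > 25000 nM, again a limit rather than a number.
Compound 3 `CCCCCNc1nc(N)nc2ccccc12`: in this assay compound 3 gives > 25000 nM, also a limit.

Compound 3 therefore stands only at a limit, as do its two neighbours; every value shown sits at the limit of > 25000 nM in this assay, at which 3 of the 3 values shown sit. Among the measured compounds shown here, the steps a step that the two limits leave unreadable from compound 1 to compound 2, a step that the two limits leave unreadable from compound 1 to compound 3 and a step that the two limits leave unreadable from compound 2 to compound 3 are all left unreadable by the limits, so no measured step gives a readable size for lengthening the chain.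

Compound 4 `COCCCNc1nc(N)nc2ccccc12` is the next member. Its change from compound 3 is methoxy in place of ethyl on a saturated chain carbon, three bonds along the chain from a nitrogen on an aromatic ring. For the measured compounds named here, no measured step bears on a methoxy entering in place of ethyl at this place, and the chain-lengthening steps that surround the change are unreadable. On the numbers shown, the step from compound 3 to compound 4 is expected to be a step that the limit leaves unreadable from compound 3 to compound 4, with nothing beyond the scatter foreseen. Compound 4 is accordingly estimated at 40000 nM in this assay, with a range from 20000 nM to 120000 nM, and most likely the assay will again report only a limit.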

Compound 4, half-maximal cytotoxic concentration: > 25000 nM
Compound 4 ended at the assay's limit; the forecaster's own chance of this, stated with the estimate: 85%; the middle value lies beyond the limit too.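

Compound 1, compound 2, compound 3 and compound 4 all stand at a limit of this assay, so no step among these four compounds can be read: the limit of > 25000 nM in this assay, at which 4 of the 4 values shown sit.

The compounds shown leave open how large any step between these side chains would be, including that from pentyl to 3-methoxypropyl, in this assay.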